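Ring Size at the Basic Amine on a Shared Core

The source may hold more compounds than are shown below. What is called first, only, known or untested is meant among the compounds shown, and "the series" means these compounds.

Of the compounds shown here, three share one core and have been tested in an assay on HEK293 cells for displacement of a labelled ligand from 5-hydroxytryptamine receptor 6 (Homo sapiens), read by radioligand binding, with a stated time of 60 min, tested at 100 nM; on this read-out higher numbers stand for more inhibition at the one concentration tested (going by the name of the read-out) and lower numbers for less inhibition. Compound 1 `O=c1sc2cc(NS(=O)(=O)c3ccccc3)ccc2n1CCN1CCCCC1` gives 6%. Compound 2 `CN(C)CCn1c(=O)sc2cc(NS(=O)(=O)c3ccc4ccccc4c3)ccc21` gives 22%. Compound 3 `O=c1sc2cc(NS(=O)(=O)c3ccc4ccccc4c3)ccc2n1CCN1CCCC1` gives 0%, the lowest of the three numbers: the gap to compound 1 lies within the scatter, while the drop a number 22 percentage points lower from compound 2 to compound 3 (beyond the scatter) lies beyond it.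

Compound 4 `O=c1sc2cc(NS(=O)(=O)c3ccc4ccccc4c3)ccc2n1CCN1CCCCC1` is not yet measured. It differs from compound 3 in one place: piperidin-1-yl in place of pyrrolidin-1-yl on a saturated chain carbon, two bonds along the chain from an aromatic nitrogen.

Within the data shown here, no measured step swaps these two rings, so the expectation rests on nearby evidence. Among the measured compounds shown here, the one swap of amine that has been measured, a number 22 percentage points lower from compound 2 to compound 3 (beyond the scatter), gave a modest drop, and compound 1, which already carries the piperidin-1-yl group, shows only 6%. A step no larger than the scatter is therefore expected, a number 8 percentage points higher from compound 3 to compound 4 (within the scatter), in either direction. The estimate for compound 4 is 8%, with a likely range from 0% to 25%.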

Compound 4, a percentage reported as inhibition, at one concentration (the size of the read-out at that concentration, not a potency): 4%
Beside the measured number, compound 4's estimate is 4 percentage points above it, within the range that was stated.
By their numbers in this assay, from the lowest: compounds 3, 4 and 1 (each within the scatter of the next); then compound 2.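

Swapping pyrrolidin-1-yl for piperidin-1-yl on this chain, one ring size for the next, makes no readable difference in this assay (a number 4 percentage points higher from compound 3 to compound 4 (within the scatter)). Both rings read apart from the open-chain dimethylamino group, since the piperidin-1-yl group now gives (a number 18 percentage points lower from compound 2 to compound 4 (beyond the scatter)) and the pyrrolidin-1-yl group gave (a number 22 percentage points lower from compound 2 to compound 3 (beyond the scatter)), so at this position the line falls between dimethylamino and the two rings, not between the rings themselves. With piperidin-1-yl held fixed, naphthalen-2-yl in place of phenyl on a sulfonyl sulfur also stays inside the noise (a number 2 percentage points lower from compound 1 to compound 4 (within the scatter)).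

Nothing measured here explains why the numbers fall this way. Still open, on these data alone, is whether diethylamino, a morpholin-4-yl ring or a longer chain to the amine would reach or pass the number of compound 2 (22%).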